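The compounds below may be only part of what the source reports. "The series", "measured", "known", "first", "only" and "open" are said of these compounds alone.

Of the compounds shown here, three sharing one core have been tested in an ADME assay on A549 cells (Homo sapiens) for cytotoxicity, read by MTT assay; a higher number here means that more compound is tolerated, a lower number that less compound is tolerated. Compound 1, `CCN(c1ccccc1C)S(=O)(=O)c1cc(Cl)ccc1Cl`, carries an ethyl group on the sulfonamide nitrogen. In this assay compound 1 reaches only a limit, > 25000 nM. Compound 2, `Cc1ccccc1NS(=O)(=O)c1cc(Cl)ccc1Cl`, carries a hydrogen on that nitrogen. Compound 2 also gives only a limit, > 5000 nM. Compound 3, `Cc1ccccc1N(C)S(=O)(=O)c1cc(Cl)ccc1Cl`, carries a methyl group on the sulfonamide nitrogen. Compound 3 likewise gives only a limit, > 5000 nM. All three values are limits, so none of the steps between them can be read: a step that the two limits leave unreadable from compound 1 to compound 2, a step that the two limits leave unreadable from compound 1 to compound 3 and a step that the two limits leave unreadable from compound 2 to compound 3 all stay unreadable. Compound 3 sits at the limit of > 5000 nM in this assay, at which 2 of the 3 values shown sit. Compound 1 sits at the limit of > 25000 nM in this assay, at which 1 of the 3 values shown sits.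

Compound 4, `C=CCN(c1ccccc1C)S(=O)(=O)c1cc(Cl)ccc1Cl`, differs from compound 3 by vinyl in place of hydrogen on a saturated chain carbon bound to a sulfonamide nitrogen. Going by the values given here, no measured step isolates this change, and the three steps that do exist show only that a hydrogen, a methyl or an ethyl on the sulfonamide nitrogen all leave the cells tolerating the compound up to the limit. Compound 4 is therefore expected to behave the same way, with no step beyond the scatter: a step that the limit leaves unreadable from compound 3 to compound 4. The estimate for compound 4 is 12000 nM, within a range of 4000 nM to 40000 nM, most likely reported again as a limit.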

Compound 4, half-maximal cytotoxic concentration: > 5000 nM
Compound 4 was reported as a limit (the forecaster's own chance of this, stated with the estimate: 80%); the middle value is on the limit's open side.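

In this assay compound 4 gives only a limit, > 5000 nM. Going by these compounds alone, compound 1, compound 2 and compound 3 also give only limits, so no step between compound 4 and any of them can be read. On these data alone, what stays open is the concentration at which any of these four compounds becomes harmful to the cells, and whether the group on the sulfonamide nitrogen affects it.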